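The source may report more compounds than this note shows. Statements on the series, on what has been measured and on what is new or still open speak of the compounds shown alone.

Compound 1 `C#CCNCc1cn(-c2cc(NC(=S)NCC)ncn2)cn1` gives 4330 nM in an assay on isolated protein for inhibition of Amine oxidase [flavin-containing] A (Homo sapiens), read by fluorescence and Amplex Red, with a stated time of 15 min; a higher number here means a weaker inhibitor, a lower number a stronger inhibitor. Compound 2 `C#CCN(Cc1cn(-c2cc(NC(=S)NCC)ncn2)cn1)C(C)=O` carries an acetyl on the amine nitrogen in place of its hydrogen, and in this assay compound 2 reaches only the limit > 50000 nM. Among the measured compounds shown here, the one measured step, an at least 11-fold higher number from compound 1 to compound 2 (1.06 log units; beyond the scatter), puts compound 2 at the limit of > 50000 nM in this assay, at which 1 of the 2 values shown sits. Compound 3 `C#CCNCCCc1cn(-c2cc(NC(=S)NCC)ncn2)cn1`, not yet measured, differs from compound 2 by a group of 6 heavy atoms (5 carbon, 1 nitrogen; no ring) in place of a group of 7 heavy atoms (5 carbon, 1 nitrogen, 1 oxygen; no ring), on a saturated chain carbon bound to an aromatic carbon, so the amine hydrogen returns on a longer chain. Because the loss in an at least 11-fold higher number from compound 1 to compound 2 (1.06 log units; beyond the scatter) came with the acetyl, compound 3 is expected to recover much of it, an estimated step of an at least 8.3-fold lower number from compound 2 to compound 3 (0.92 log units; beyond the scatter). For compound 3 the estimate is 6000 nM, expected between 1500 nM and 25000 nM.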

Compound 3, half-maximal inhibitory concentration: > 50000 nM
Compound 3 was reported as a limit (the forecaster's own chance of this, stated with the estimate: 15%); at least 8.3-fold (0.92 log units) between middle value and limit.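

Keeping the amine hydrogen is not enough to hold activity: 2-(propargylamino)ethyl in place of propargylamino on a saturated chain carbon bound to an aromatic carbon gives an at least 11-fold higher number from compound 1 to compound 3 (1.06 log units; beyond the scatter) in this assay, so this position tolerates the longer chain no better than the acetyl. Compound 2 and compound 3 both end at a limit rather than a number, and the step between them cannot be read: the limit of > 50000 nM in this assay, at which 2 of the 3 values shown sit.

Going by these compounds, how much weaker either compound truly is stays open, as does whether a methyl on the amine nitrogen of compound 1 would be tolerated.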